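Vinyl to (phenylsulfanyl)methyl on the chain of compound 2

The source may report more compounds than this note shows. Statements on the series, on what has been measured and on what is new or still open speak of the compounds shown alone.

Measured so far, read-out a functional assay on the whole organism with Rattus norvegicus as the target; on this read-out lower numbers stand for an effect already at smaller amounts and higher numbers for an effect only at larger amounts of compound:
compound 1 `Nc1nc2ccc(C(=O)C(F)(F)F)cc2s1` gives > 10 mg/kg
compound 2 `C=CCn1c(=N)sc2cc(OC(F)(F)F)ccc21` gives 7 mg/kg

The value of compound 1 in this assay is a limit of the assay and not a number. Among the measured compounds shown here, compound 2 therefore supplies the only number in this assay; the other entry is the limit described by the limit of > 10 mg/kg in this assay, at which 1 of the 2 values shown sits. For the measured compounds named here, no pair of measured compounds differs in a single place, so no measured step is available to anchor what a change at the chain should do.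

Compound 3 `N=c1sc2cc(OC(F)(F)F)ccc2n1CCSc1ccccc1` is not yet measured in this assay. Its difference from compound 2 is (phenylsulfanyl)methyl in place of vinyl on a saturated chain carbon bound to an aromatic nitrogen. The new group is larger and carries one hydrogen-bond acceptor where the vinyl had none, and it sits on a saturated chain carbon bound to an aromatic nitrogen. With nothing measured at this position, the expected step from compound 2 to compound 3 is none beyond the usual scatter, written as no change at the digits printed from compound 2 to compound 3 (within the scatter). On that basis compound 3 is estimated at 7 mg/kg in this assay, with a range from 3 mg/kg to 20 mg/kg; a result reported only as a limit remains possible.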

Compound 3, dose for half-maximal effect: 4.5 mg/kg
Compound 3: the middle estimate sits 1.6-fold (0.19 log units) above what was measured, within the range that was stated.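

In this assay the chain now has its first measured step, a 1.6-fold lower number from compound 2 to compound 3 (0.19 log units; within the scatter), and this step shows that the read-out at this position does not separate the two groups. A saturated chain carbon bound to an aromatic nitrogen can therefore carry (phenylsulfanyl)methyl, with its 8 heavy atoms, one six-membered aromatic ring of carbon only and 1 hydrogen-bond acceptor, in place of the 2 heavy atoms of vinyl, without the result leaving the usual scatter. Among the compounds shown here, this holds for this single pair only, and compound 1 differs from both compounds in more than one place, so no step to it can be read.

Still open, from the compounds shown here alone, is whether a shorter or longer chain, an oxygen in place of the sulfur, or an amine or a carboxylic acid on the terminal aromatic ring would keep the read-out within the scatter or move it beyond. The data shown include no measured property that could account for the step between vinyl and (phenylsulfanyl)methyl.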